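This account rests on a few compounds, and the source may have more. Where it says the series, first, only, none or still open, it means among the compounds named here.

Compound 3 `Nc1nc(N)c2cc(CSC(=S)N3CCN(c4ccccc4Cl)CC3)ccc2n1` sits second highest of the three values in a functional assay on HCT-116 cells (Homo sapiens) for antiproliferative activity, read by MTT assay, with a stated time of 72 h; a higher number here means a weaker inhibitor, a lower number a stronger inhibitor. Compound 1 `Nc1nc(N)c2cc(CSC(=S)N3CCN(C4CCCCC4)CC3)ccc2n1` gives 8400 nM, compound 2 `COc1ccc(N2CCN(C(=S)SCc3ccc4nc(N)nc(N)c4c3)CC2)cc1` gives 2270 nM, and compound 3 gives 5490 nM. The step of a 1.5-fold lower number from compound 1 to compound 3 (0.18 log units; within the scatter) lies within the scatter, whereas a 2.4-fold higher number from compound 2 to compound 3 (0.38 log units; beyond the scatter) is a modest worsening, and a 3.7-fold lower number from compound 1 to compound 2 (0.57 log units; beyond the scatter) is a modest improvement.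

Compound 4 `Nc1nc(N)c2cc(CSC(=S)N3CCN(c4ncccn4)CC3)ccc2n1` differs from compound 3 in one place: pyrimidin-2-yl in place of 2-chlorophenyl on an amine nitrogen in a ring. For the measured compounds named here, the measured steps on this ring nitrogen cover a cyclohexyl, a 4-methoxyphenyl and a 2-chlorophenyl; none involves a ring with two hetero atoms, so no step speaks to the pyrimidin-2-yl directly. Going by the values given here, the steps that bear on it, a 1.5-fold lower number from compound 1 to compound 3 (0.18 log units; within the scatter) and a 2.4-fold higher number from compound 2 to compound 3 (0.38 log units; beyond the scatter), show that exchanging the group on this nitrogen has shifted the number by no more than a modest amount in either direction. On that basis the exchange to pyrimidin-2-yl is expected to leave the number close to that of compound 3, with no change beyond the scatter or at most a modest one, expected as a 1.1-fold lower number from compound 3 to compound 4 (0.04 log units; within the scatter). Compound 4 is therefore estimated at 5000 nM in this assay, within a range from 2000 nM to 12000 nM.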

Compound 4, half-maximal inhibitory concentration: 5840 nM
The estimate for compound 4 lay 1.2-fold (0.07 log units) below the measured number, and the stated range covers the measured number.
By their numbers in this assay, from the lowest: compound 2; then compounds 3, 4 and 1 (each within the scatter of the next).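

In this assay, for the compounds shown here, pyrimidin-2-yl is the first group on this amine nitrogen with hetero atoms in its ring and with hydrogen-bond acceptors of its own, yet the exchange for 2-chlorophenyl gives no change that can be told from the scatter (a 1.1-fold higher number from compound 3 to compound 4 (0.03 log units; within the scatter)), and the same holds for the exchange for cyclohexyl (a 1.4-fold lower number from compound 1 to compound 4 (0.16 log units; within the scatter)). Compounds 1, 3 and 4 thus form a single group despite a saturated carbon ring, a chlorine-bearing aromatic ring and a ring with two nitrogens at this position, while compound 2 with its 4-methoxyphenyl remains the only one set apart, as the strongest of the four (a 2.6-fold higher number from compound 2 to compound 4 (0.41 log units; beyond the scatter)). No measurement at hand accounts for this flat response or for the separate standing of compound 2.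

From the compounds shown here alone, it remains open whether the advantage of compound 2 belongs to the methoxy group or to its place on the phenyl ring, a question that plain phenyl, 2-methoxyphenyl or 4-chlorophenyl on this nitrogen would address. Going by these compounds, it is also open whether a 4-methoxy group on a pyrimidine or pyridine ring would keep that advantage.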